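The source may hold more compounds than are shown below. What is called first, only, known or untested is meant among the compounds shown, and "the series" means these compounds.

Measured compounds in a toxicity assay on WI-38 cells (Homo sapiens) for cytotoxicity, read by MTT assay, with a stated time of 48 h; a lower number here means a stronger inhibitor, a higher number a weaker inhibitor:
Compound 1 `O=C(/C=C/c1ccc2c(c1)B(O)OC2)c1cccnc1` gives 76200 nM.
Compound 2 `O=C(/C=C/c1ccc2c(c1)B(O)OC2)c1ccc(OCc2ccccc2)cc1` reaches only a limit of the assay, > 100000 nM.
Compound 3 `Cc1ccc(C(=O)/C=C/c2ccc3c(c2)B(O)OC3)cc1C` gives 22000 nM.

Of the two numbers in this assay, compound 1 stands highest, that is, as the weaker inhibitor; compound 3 lies lower by a margin beyond the usual scatter. The remaining value is not a number but a limit, (the limit of > 100000 nM in this assay, at which 1 of the 3 values shown sits), and compound 2 is the compound at that limit. Among the measured compounds shown here, all three share the same core carrying the unsaturated ketone; they differ only in the aryl group on the carbonyl carbon, and no pair among them differs in a single place, so no measured step is available to calibrate the next change.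

Compound 4 `Nc1cccc(C(=O)/C=C/c2ccc3c(c2)B(O)OC3)c1` is not yet measured in this assay. It departs from compound 1 as follows: 3-aminophenyl in place of pyridin-3-yl on a carbonyl carbon. Across the three measured compounds the aryl group on the carbonyl carbon moves the value only modestly, and nothing in the measured set points to either direction for this particular exchange. For compound 4 the step of a 1.2-fold lower number from compound 1 to compound 4 (0.07 log units; within the scatter) is therefore expected to lie within the scatter, with no change beyond it. Compound 4 is estimated at 65000 nM, in the range 25000 nM to 170000 nM.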

Compound 4, half-maximal inhibitory concentration: 25300 nM
Beside the measured number, compound 4's estimate is 2.6-fold (0.41 log units) above it; the measured number falls inside the stated range.
By their numbers in this assay, from the lowest: compounds 3 and 4 (each within the scatter of the next); then compound 1. At a limit, above all of these: compound 2.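

In this assay, the aryl group on a carbonyl carbon now has its first measured single-place step: a 3.0-fold lower number from compound 1 to compound 4 (0.48 log units; beyond the scatter), with 3-aminophenyl in place of pyridin-3-yl. The step shows that this position can move the number beyond the scatter with the shared core and the unsaturated ketone left unchanged, an exchange that replaces a ring with one hetero atom by a ring of carbon only and gains a hydrogen-bond donor. These differences arrive together in one exchange, and nothing measured in this set separates them or gives a cause for the step.

Still open, going by these compounds, is which part of the exchange carries the step, since plain phenyl on the carbonyl carbon would set the ring nitrogen of compound 1 apart from the amine of compound 4. Also open, on these data alone, is whether the amine itself matters, which a hydroxyl or a dimethylamino group in its place, read against compound 4 in this assay, would begin to show.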